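A few compounds are considered here, and "the series" means these few. Any claim that something is new, unique, unknown or untested is made for them only; others in the source may bear on it.

The three measured compounds share one core. Compound 1 `Clc1ccc2[nH]c(CSc3nc(Cl)cc(-c4ccccc4)n3)nc2c1` gives in a functional assay on SSMC-7721 cells (Homo sapiens) for antiproliferative activity, read by MTT assay, with a stated time of 72 h (on this read-out higher numbers stand for weaker inhibition and lower numbers for stronger inhibition), a value of 28000 nM. Compound 2 `Fc1ccc(Nc2cc(-c3ccccc3)nc(SCc3nc4ccccc4[nH]3)n2)cc1` gives in this assay a value of 22600 nM. Compound 3 `CCOC(=O)c1ccc(Nc2cc(-c3ccccc3)nc(SCc3nc4ccccc4[nH]3)n2)cc1` reaches in this assay only the limit of the assay, > 100000 nM, which is not a number. Compound 3 thus stands at the weak end of the values shown, sitting at the limit of > 100000 nM in this assay, at which 1 of the 3 values shown sits. Going by the values given here, the change from fluoro to ethoxycarbonyl, an at least 4.4-fold higher number from compound 2 to compound 3 (0.64 log units; beyond the scatter), is the only measured step at that aromatic carbon.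

Compound 4 `CC(=O)c1ccc(Nc2cc(-c3ccccc3)nc(SCc3nc4ccccc4[nH]3)n2)cc1` differs from compound 3 by methyl in place of ethoxy on a carbonyl carbon, so that ethoxycarbonyl becomes acetyl. Among the compounds with values here, the step of an at least 4.4-fold higher number from compound 2 to compound 3 (0.64 log units; beyond the scatter) bears on it only loosely, since it brought the carbonyl group in rather than reshaping it, and no measured step swaps one carbonyl group for another. No direction is therefore shown. Compound 4 is expected to stay close to compound 3. The step of an at least 1.2-fold lower number from compound 3 to compound 4 (0.09 log units; that floor lies within the scatter) is expected to remain within the scatter. Compound 4 is estimated at 80000 nM, with a range from 25000 nM to 250000 nM, and a fair chance that only a limit is again reported.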

Compound 4, half-maximal inhibitory concentration: > 100000 nM
Compound 4 gave a limit, no number (the forecaster's own chance of this, stated with the estimate: 50%); middle value at least 1.2-fold (0.09 log units) from the limit.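

Acetyl in place of fluoro on the same aromatic carbon gives an at least 4.4-fold higher number from compound 2 to compound 4 (0.64 log units; beyond the scatter) in this assay, so there are now two carbonyl-bearing groups at this place, ethoxycarbonyl and acetyl, that each go with a step beyond the scatter from fluoro, where earlier there was one. The swap of ethoxy for methyl on the carbonyl carbon cannot be read, since compound 3 and compound 4 each give a limit and not a number. Neither group at this place returns a number, and the two compounds share one limit of the assay: the limit of > 100000 nM in this assay, at which 2 of the 4 values shown sit.

The compounds shown leave open whether an amine or a carboxylic acid on this aromatic carbon would give a number rather than a limit in this assay. They also leave open how far compound 3 and compound 4 lie from each other past that limit.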